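Cyclobutyl amide replaces oxanyl ethyl chain on aminopyridine

A few compounds are considered here, and "the series" means these few. Any claim that something is new, unique, unknown or untested is made for them only; others in the source may bear on it.

Compound 2 `N#Cc1cnc(NCc2cnccc2C(F)(F)F)cc1NCCC1CCOCC1` is the weaker of the two measured compounds. In an assay on isolated protein for inhibition of protein kinase C delta type (Homo sapiens), read by TR-FRET, with a stated time of 2 h (a lower number here means a stronger inhibitor, a higher number a weaker inhibitor), compound 2 gives only a limit, > 10000 nM, and no number. Within the data shown here, compound 1 `N#Cc1cnc(NCc2cnccc2C(F)(F)F)cc1NC[C@H]1C[C@@H](O)C1` gives 4200 nM in this assay, and the step of an at least 2.3-fold higher number from compound 1 to compound 2 (0.37 log units; beyond the scatter) is the only measured step here; it is itself bounded by the limit of > 10000 nM in this assay, at which 1 of the 2 values shown sits.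

Compound 3 `CC1(C)[C@H](Nc2cc(NCc3cnccc3C(F)(F)F)ncc2C#N)C[C@H]1C(N)=O` has not been measured. Its difference from compound 2 is 3-carbamoyl-2,2-dimethylcyclobutyl in place of 2-(oxan-4-yl)ethyl on a nitrogen on an aromatic ring. Among the measured compounds shown here, no measured step matches this change exactly; the step from compound 1 to compound 2 is the nearest, since it exchanged a hydroxyl-bearing cyclobutyl, joined through a chain carbon, for the oxanyl chain and made the number at least modestly higher. Compound 3 brings back a cyclobutyl ring with one hydrogen-bond donor, now bound directly to the aromatic nitrogen, so a return toward the number of compound 1 is the most natural expectation, without a firm anchor for its size.

Compound 3 is therefore estimated at 3000 nM in this assay, with a range from 700 nM to 10000 nM, which means an expected step of an at least 3.3-fold lower number from compound 2 to compound 3 (0.52 log units; beyond the scatter).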

Compound 3, half-maximal inhibitory concentration: 900 nM
Compound 3: middle estimate off by 3.3-fold (0.52 log units), on the high side, within the range that was stated.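

Among these compounds, compound 3 shows that the substituent on the aromatic nitrogen can do more than recover the number of compound 1 in this assay: replacing (3-hydroxycyclobutyl)methyl with 3-carbamoyl-2,2-dimethylcyclobutyl gives a 4.7-fold lower number from compound 1 to compound 3 (0.67 log units; beyond the scatter), the first step here measured between two actual numbers. Replacing 2-(oxan-4-yl)ethyl with the same group gives an at least 11-fold lower number from compound 2 to compound 3 (1.04 log units; beyond the scatter), which widens the spread at this position well beyond what the earlier pair could show. The value for compound 2 remains a limit, so this larger step carries that bound as well: the limit of > 10000 nM in this assay, at which 1 of the 3 values shown sits.

Compound 3 differs from both compound 1 and compound 2 in several features of one substituent at once, namely the carbamoyl group, the two methyl groups, the ring and the direct attachment to the nitrogen, so the compounds shown do not tell which of these accounts for the steps. From the compounds shown here alone, it also remains open how a carboxylic acid or a primary amine in place of the carbamoyl group, or a cyclobutyl ring without the two methyl groups, would read in this assay.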